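A Halogen Swap Repeated on a Second Benzimidazole Core

The source may hold more compounds than are shown below. What is called first, only, known or untested is meant among the compounds shown, and "the series" means these compounds.

The measurements here come from a functional assay on A549 cells (Homo sapiens) for cytotoxicity, read by MTT assay, with a stated time of 48 h (on this read-out lower numbers stand for stronger inhibition and higher numbers for weaker inhibition), which reports the concentration of a compound needed to inhibit the growth of a lung-cancer cell line. Compound 1 `Cc1ccc(Cn2c(/C=C3\SC(=S)N(CC(=O)O)C3=O)nc3ccc(Cl)cc32)cc1` gives 9970 nM in this assay. Compound 2 `Cc1ccc(Cn2c(/C=C3\SC(=S)N(CC(=O)O)C3=O)nc3ccc(F)cc32)cc1` differs from it only by fluoro in place of chloro on an aromatic carbon, and in this assay compound 2 gives 9640 nM. The step is a 1.0-fold lower number from compound 1 to compound 2 (0.01 log units; within the scatter), so the swap of one halogen for the other left the read-out essentially unchanged.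

Compound 3 `O=C(O)CN1C(=O)/C(=C/c2nc3cc(Cl)ccc3n2Cc2ccccc2F)SC1=S` carries a different core; the difference between the core of compound 1 and the core of compound 3 is not broken down here. In this assay compound 3 gives 5640 nM, a number that sits within the usual scatter of both compound 1 and compound 2, so no ordering among the three can be claimed.

Compound 4 `O=C(O)CN1C(=O)/C(=C/c2nc3cc(F)ccc3n2Cc2ccccc2F)SC1=S` has not yet been measured. It differs from compound 3 by fluoro in place of chloro on an aromatic carbon. The place of this change reads word for word as it does for the earlier pair, so it is the same change applied to the second core. From compound 3 to compound 4 a step of a 1.0-fold lower number from compound 3 to compound 4 (0.00 log units; within the scatter) is expected, because the same change gave a 1.0-fold lower number from compound 1 to compound 2 (0.01 log units; within the scatter). Compound 4 is therefore estimated to give about 5600 nM in this assay. For compound 4 the expected range runs from 2600 nM to 12000 nM, resting on a single earlier example of the change.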

Compound 4, half-maximal inhibitory concentration: 32700 nM
Compound 4: middle estimate off by 5.8-fold (0.77 log units), on the low side; measured number above the stated range.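

In this assay, fluoro in place of chloro on an aromatic carbon was silent on the first core but not on the second, where the swap gave a 5.8-fold higher number from compound 3 to compound 4 (0.76 log units; beyond the scatter), which here means weaker inhibition of the cells. The same change therefore did not carry over from one core to the other with the same size: the same change on two cores in this assay, a 1.0-fold lower number (0.01 log units; within the scatter) from compound 1 to compound 2 and a 5.8-fold higher number (0.76 log units; beyond the scatter) from compound 3 to compound 4, 6.0-fold (0.78 log units) apart, beyond the scatter of two such steps. This shows that, in this series, a step seen on one core is not a safe guide to the step on another, but it does not show which difference between the two cores is responsible or why, and two pairs cannot set a rule for the wider series.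

The compounds shown leave open whether the jump on the second core is specific to fluoro, since no other group, such as bromo, methoxy or a plain hydrogen, appears on that aromatic carbon for comparison. They also leave open how the remaining parts of the two cores contribute, which could be tested by changing one part at a time, for instance by moving the methyl group of compound 1 onto the benzyl ring of compound 3 in place of its fluoro.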